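Chlorobenzyl positional swap across two related cores

The source may hold more compounds than are shown below. What is called first, only, known or untested is meant among the compounds shown, and "the series" means these compounds.

Compound 1 `COc1ccc(C2N=C(SCc3cccc(Cl)c3)NC(C)=C2C(=O)Nc2ccc(F)cc2)cc1OC` and compound 2 `COc1ccc(C2N=C(SCc3ccc(Cl)cc3)NC(C)=C2C(=O)Nc2ccc(F)cc2)cc1OC` share one core; compound 3 `COc1ccc(C2N=C(SCc3cccc(Cl)c3)NC(C)=C2C(=O)Nc2ccc(Br)cc2)cc1` and compound 4 `COc1ccc(C2N=C(SCc3ccc(Cl)cc3)NC(C)=C2C(=O)Nc2ccc(Br)cc2)cc1` share another. The difference between the two cores is not broken down here. In a functional assay on the whole organism (artery, strain albino) with Rattus norvegicus as the target, with a stated time of 30 min, at a dose of 10 mg/kg by the oral route (on this read-out lower numbers stand for less inhibition and higher numbers for more inhibition at the one dose given (going by the name of the read-out)), compound 1 gives 5.2%, compound 2 gives 5.7% and compound 3 gives 7.7%. All three numbers lie within the scatter of one another, so no order among them is read.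

On the core of compound 1 the measured change is 4-chlorophenyl in place of 3-chlorophenyl on a saturated chain carbon bound to a sulfur; it made a number 0.5 percentage points higher from compound 1 to compound 2 (within the scatter). Compound 4 carries the same change on the core of compound 3: 4-chlorophenyl in place of 3-chlorophenyl on a saturated chain carbon bound to a sulfur. Among the compounds shown this change occurs only twice, so the expectation rests on a single measured pair.

In this assay, for the measured compounds named here, the step expected here is a number 0.5 percentage points higher from compound 3 to compound 4 (within the scatter), because a number 0.5 percentage points higher from compound 1 to compound 2 (within the scatter) and no compound indicates that the second core would answer the change differently. Compound 4 is therefore estimated at 8.2% in this assay, with the expected range running from 0% to 18%.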

Compound 4, a percentage reported as inhibition, in the whole organism at one dose (the size of the read-out at that dose, not a potency): 7.2%
Estimate against measurement, compound 4: 1 percentage points above; the range from low to high includes it.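

On the second core, the swap of 3-chlorophenyl for 4-chlorophenyl gave a number 0.5 percentage points lower from compound 3 to compound 4 (within the scatter). Set beside the earlier step in this assay, the two do not differ: the same change on two cores in this assay, a number 0.5 percentage points higher (within the scatter) from compound 1 to compound 2 and a number 0.5 percentage points lower (within the scatter) from compound 3 to compound 4, 1 percentage points apart, within the scatter of two such steps. For the compounds shown here, this shows only that carrying the change from one core to the other produced no readable difference in this read-out; it does not show that the change acts alike on both cores, as neither step can be told from no effect, and two cores at one dose give no basis for a rule across the series.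

The compounds shown leave open whether any group at this place, on a saturated chain carbon bound to a sulfur, would shift the read-out, as all four carry a chlorophenyl there and a carboxylic acid, an amine or a longer chain is not among them. Also open, on these data alone, is whether the swap would stay without a readable effect on a core where the read-out itself lies higher.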